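Compound 4: a Fluoro Added to Compound 1

A few compounds are considered here, and "the series" means these few. Any claim that something is new, unique, unknown or untested is made for them only; others in the source may bear on it.

Compound 1, `COc1ccc(-c2ccc(-c3ccc(C(=N)N)cc3)s2)cc1`, 773 nM
Compound 2, `N=C(N)c1ccc(-c2ccc(-c3ccc(F)cc3)s2)cc1`, 1590 nM
Compound 3, `N=C(N)c1ccc(-c2ccc(-c3ccc(Cl)cc3)s2)cc1`, 164 nM

In a functional assay on PC-3 cells (Homo sapiens) for inhibition, read by sulforhodamine B assay, with a stated time of 48 h (a lower number here means a stronger inhibitor of growth, a higher number a weaker inhibitor of growth), compound 1 gives 773 nM, the second highest of the three numbers. Its nearest neighbour is compound 2, reached by fluoro in place of methoxy on an aromatic carbon, and that step gives a 2.1-fold higher number from compound 1 to compound 2 (0.31 log units; beyond the scatter). Furthest from it is compound 3, where chloro takes the place of methoxy, and that step gives a 4.7-fold lower number from compound 1 to compound 3 (0.67 log units; beyond the scatter). Between the two halogens, chloro in place of fluoro gives a 9.7-fold lower number from compound 2 to compound 3 (0.99 log units; beyond the scatter).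

Compound 4, `COc1ccc(-c2ccc(-c3ccc(C(=N)N)c(F)c3)s2)cc1`, differs from compound 1 by fluoro in place of hydrogen on an aromatic carbon. None of the three measured steps touches the same place: each of them exchanges the group that is methoxy in compound 1, whereas compound 4 keeps that methoxy and adds a fluoro on the ring that carries the group of 3 heavy atoms. Within the data shown here, the measured steps therefore give no direct guide to this change; they show only that exchanges of the methoxy moved the number by modest amounts in either direction. Among the measured compounds shown here, with no step bearing on the added fluoro, compound 4 is expected to stay close to compound 1, so that a 1.0-fold lower number from compound 1 to compound 4 (0.01 log units; within the scatter) is expected to be no step beyond the scatter. Compound 4 is accordingly estimated at 750 nM in this assay, with an expected range from 250 nM to 2200 nM.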

Compound 4, concentration for 50% growth inhibition: 4050 nM
Compound 4: middle estimate off by 5.4-fold (0.73 log units), on the low side; measured number above the stated range.
By their numbers in this assay, from the lowest: compound 3; then compound 1; then compound 2; then compound 4.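

In this assay, fluoro in place of hydrogen on an aromatic carbon, ortho to a group of 3 heavy atoms and meta to a large group, gives a 5.2-fold higher number from compound 1 to compound 4 (0.72 log units; beyond the scatter), so this position is not a silent one even when the methoxy stays as it is. Among these compounds, the earlier steps all exchanged the methoxy, and this is the first sign that the ring carrying the group of 3 heavy atoms also responds to substitution, with a single added fluorine moving the number towards a weaker inhibitor of growth. Nothing at hand explains why this added fluoro has this result.

The compounds shown leave open whether the rise belongs to fluoro itself or would also follow from a chloro, a methyl or a hydroxyl at this same place. They also leave open whether the same added fluoro would shift the number in the same direction on the chloro-bearing compound 3, or on the fluoro-bearing compound 2, where the methoxy is already exchanged.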